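The compounds below may be only part of what the source reports. "The series", "measured", "known", "first", "only" and "open" are said of these compounds alone.

Measured compounds in an assay on isolated protein for binding affinity to Type-2 angiotensin II receptor (Homo sapiens); on this read-out lower numbers stand for stronger inhibition and higher numbers for weaker inhibition:
compound 1 `CCCc1nc(CC)c(C(=O)OCCC[S+]([O-])c2ccccc2)n1Cc1ccc(-c2ccccc2S(=O)(=O)NC(=O)OCCC(C)C)cc1F`, giving 1 nM
compound 2 `CCCc1nc(CC)c(C(=O)NCCCOc2ccccc2)n1Cc1ccc(-c2ccccc2S(=O)(=O)NC(=O)OCCC(C)C)cc1F`, giving 9 nM

Going by the values given here, compound 1 holds the lowest of the two numbers; its nearest neighbour is compound 2, and the single measured step, a 9.0-fold higher number from compound 1 to compound 2 (0.95 log units; beyond the scatter), separates them. Among the compounds with values here, that step changes the group on the carbonyl carbon and is the only guide available.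

Compound 3 `CCCc1nc(CC)c(C(=O)OCc2ccccc2-c2ccccc2)n1Cc1ccc(-c2ccccc2S(=O)(=O)NC(=O)OCCC(C)C)cc1F` has not been measured. It differs from compound 1 as follows: a group of 12 heavy atoms (12 carbon; 2 six-membered aromatic rings of carbon only) in place of a group of 10 heavy atoms (8 carbon, 1 oxygen, 1 sulfur; one six-membered aromatic ring of carbon only), on a saturated chain carbon bound to an oxygen next to a carbonyl group. The ester linkage of compound 1 is kept, so the change sits within the chain beyond the carbonyl rather than at the carbonyl itself. Within the data shown here, the one measured step shows that reworking this region of the shared core costs a modest amount, and a similar or smaller loss is expected here, since compound 2 moved by a 9.0-fold higher number from compound 1 to compound 2 (0.95 log units; beyond the scatter) with a larger alteration. For compound 3 a step of a 4.0-fold higher number from compound 1 to compound 3 (0.60 log units; beyond the scatter) in this assay is therefore expected, giving an estimated 4 nM with a range of 1 nM to 20 nM.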

Compound 3, half-maximal inhibitory concentration: 9 nM
Compound 3: the middle estimate sits 2.3-fold (0.35 log units) below what was measured; low and high end bracket the measured number.
By their numbers in this assay, from the lowest: compound 1; then compounds 2 and 3 (each within the scatter of the next).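

In this assay, a change confined to the part beyond the ester linkage, with 2-phenylphenyl entering on a saturated chain carbon bound to an oxygen next to a carbonyl group, gives a 9.0-fold higher number from compound 1 to compound 3 (0.95 log units; beyond the scatter) and so shows that keeping the ester does not by itself keep the low number of compound 1. This step prints the same size as a 9.0-fold higher number from compound 1 to compound 2 (0.95 log units; beyond the scatter), so the group of compound 1 that holds sulfur and oxygen has now been replaced in two different ways, each with a rise beyond the scatter. Nothing available explains the rise.

Open, on these data alone, is whether a plain benzyl ester or a longer chain ending in phenyl would recover the number of compound 1. Also open, as far as these compounds go, is how the sulfur-containing group of compound 1 behaves on an amide.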